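Cytotoxicity notes: compound 2 to compound 4

The source may hold more compounds than are shown below. What is called first, only, known or untested is meant among the compounds shown, and "the series" means these compounds.

Compound 2 `COC(=O)C(=O)CNC1=CS(=O)(=O)O[C@@]12[C@@H](CO[Si](C)(C)C(C)(C)C)O[C@@H](n1cc(C)c(=O)n(C)c1=O)[C@@H]2O[Si](C)(C)C(C)(C)C` carries a ((methoxycarbonyl)carbonyl)methyl group on the amine nitrogen of the shared core. In a functional assay on HEL cells (Homo sapiens) for cytotoxicity, read by microscopy (on this read-out higher numbers stand for lower toxicity in this test and lower numbers for higher toxicity in this test), compound 2 gives > 400000 nM, which is a limit of the assay and not a number (the limit of > 400000 nM in this assay, at which 1 of the 3 values shown sits). Its neighbours are known only as limits as well. Compound 1 `Cc1cn([C@@H]2O[C@H](CO[Si](C)(C)C(C)(C)C)[C@@]3(OS(=O)(=O)C=C3NC(=O)c3ccccc3)[C@H]2O[Si](C)(C)C(C)(C)C)c(=O)n(C)c1=O` gives >= 3200 nM in this assay, a limit (the limit of >= 3200 nM in this assay, at which 1 of the 3 values shown sits). Compound 3 `COC(=O)CNC1=CS(=O)(=O)O[C@@]12[C@@H](CO[Si](C)(C)C(C)(C)C)O[C@@H](n1cc(C)c(=O)n(C)c1=O)[C@@H]2O[Si](C)(C)C(C)(C)C` gives >= 400000 nM in this assay, again a limit (the limit of >= 400000 nM in this assay, at which 1 of the 3 values shown sits). The steps a step that the two limits leave unreadable from compound 1 to compound 2 and a step that the two limits leave unreadable from compound 2 to compound 3 therefore cannot be sized, and the same holds for a step that the two limits leave unreadable from compound 1 to compound 3; all three compounds sit at limits and nothing among them reads as a measured step.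

Compound 4 `Cc1cn([C@@H]2O[C@H](CO[Si](C)(C)C(C)(C)C)[C@@]3(OS(=O)(=O)C=C3NCC(=O)C(N)=O)[C@H]2O[Si](C)(C)C(C)(C)C)c(=O)n(C)c1=O` differs from compound 2 by amino in place of methoxy on a carbonyl carbon. Of the two steps that touch compound 2, one exchanges the whole group on the amine nitrogen and one changes the carbonyl-side end of that group; neither gives a readable size, so no direction can be drawn from them. The two compounds that hold the (methoxycarbonyl) motif, compound 2 and compound 3, both sit at the upper limit of this assay, and compound 4 is expected to do the same, so the step of a number no higher from compound 2 to compound 4 (the limit leaves the size open) is expected to be nothing beyond the scatter. Compound 4 is therefore estimated at 400000 nM, within 200000 nM to 800000 nM, most likely reported only as a limit.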

Compound 4, minimum cytotoxic concentration: >= 16000 nM
Compound 4 was reported as a limit (the forecaster's own chance of this, stated with the estimate: 85%); the middle value lies beyond the limit too.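

In this assay compound 4 gives >= 16000 nM, which is a limit of the assay and not a number. Among the compounds shown here, compound 1, compound 2 and compound 3 are also known only as limits, so no step to compound 4 can be read. The compounds shown leave open whether any exchange of the group on the amine nitrogen, including (carbamoylcarbonyl)methyl, shifts this read-out at all.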